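Aryl-for-alkyl swaps on the isoxazole side chain of the series

This account rests on a few compounds, and the source may have more. Where it says the series, first, only, none or still open, it means among the compounds named here.

Compound 3 `CC(=O)OC[C@H]1O[C@@H](n2cc(-c3cc(C)no3)c(=O)[nH]c2=O)C[C@@H]1OC(C)=O` gives 90.8% in a functional assay on NUGC-3 cells (Homo sapiens) for cytotoxicity, read by sulforhodamine B assay, tested at 10 uM; on this read-out lower numbers stand for less inhibition and higher numbers for more inhibition at the one concentration tested (going by the name of the read-out). Compound 1 `CCCc1cc(-c2cn([C@H]3C[C@H](OC(C)=O)[C@@H](COC(C)=O)O3)c(=O)[nH]c2=O)on1` gives 89.1%, and the step of a number 1.7 percentage points higher from compound 1 to compound 3 (within the scatter) keeps both within the scatter of each other. Compound 2 `CCc1ccc(-c2cc(-c3cn([C@H]4C[C@H](OC(C)=O)[C@@H](COC(C)=O)O4)c(=O)[nH]c3=O)on2)cc1` gives 72.6%; the steps of a number 16.5 percentage points lower from compound 1 to compound 2 (beyond the scatter) and a number 18.2 percentage points higher from compound 2 to compound 3 (beyond the scatter) are both beyond the scatter, so compound 2 sits clearly under the other two.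

Compound 4 `CCCCc1ccc(-c2cc(-c3cn([C@H]4C[C@H](OC(C)=O)[C@@H](COC(C)=O)O4)c(=O)[nH]c3=O)on2)cc1` differs from compound 3 by 4-butylphenyl in place of methyl on an aromatic carbon. The step that bears on it is a number 18.2 percentage points higher from compound 2 to compound 3 (beyond the scatter), read in reverse, together with a number 16.5 percentage points lower from compound 1 to compound 2 (beyond the scatter): each time the aryl group replaced an alkyl group the number fell modestly. A drop of similar size is therefore expected for compound 4, the step of a number 22.8 percentage points lower from compound 3 to compound 4 (beyond the scatter) being estimated downward beyond the scatter. Compound 4 is estimated at 68%, in the range 50% to 84%.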

Compound 4, a percentage reported as inhibition, at one concentration (the size of the read-out at that concentration, not a potency): 39.8%
Estimate against measurement, compound 4: 28.2 percentage points above; measured number below the stated range.
By their numbers in this assay, from the lowest: compound 4; then compound 2; then compounds 1 and 3 (each within the scatter of the next).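

In this assay the aryl swap at this position is not a fixed modest drop, since a number 51 percentage points lower from compound 3 to compound 4 (beyond the scatter) and a number 49.3 percentage points lower from compound 1 to compound 4 (beyond the scatter) are both large. The chain on the aryl group also counts, with a number 32.8 percentage points lower from compound 2 to compound 4 (beyond the scatter) on going from 4-ethylphenyl to 4-butylphenyl. The same chain change carries different weight on the alkyl and aryl compounds: the same change on two cores in this assay, a number 1.7 percentage points higher (within the scatter) from compound 1 to compound 3 and a number 32.8 percentage points higher (beyond the scatter) from compound 4 to compound 2, 31.1 percentage points apart, beyond the scatter of two such steps.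

Going by these compounds, whether the number keeps falling with a longer chain on the phenyl ring remains open. Also open, on these data alone, is how unsubstituted phenyl or a phenyl ring bearing an amine would compare.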